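Half-life notes: thiophen-2-yl in place of 2-fluorophenyl

The source may hold more compounds than are shown below. What is called first, only, known or untested is meant among the compounds shown, and "the series" means these compounds.

In a physicochemical assay for pharmacokinetics (a lower number here means that the compound disappears faster, a higher number that the compound lasts longer), compound 2 (`O=C(NCc1ccccc1F)N1C(=O)c2ccccc2S1(=O)=O`) gives 0.598 h and stands within the scatter of compound 1 (`CC(NC(=O)N1C(=O)c2ccccc2S1(=O)=O)c1ccccc1`) at 0.663 h in the same measurement. Compound 3 (`O=C(NCc1ccc(C(F)(F)F)cc1)N1C(=O)c2ccccc2S1(=O)=O`) gives 0.212 h and lies lower than compound 2 by more than the scatter.

Compound 4 (`O=C(NCc1cccs1)N1C(=O)c2ccccc2S1(=O)=O`) is still unmeasured. It carries thiophen-2-yl in place of 2-fluorophenyl on a saturated chain carbon bound to an amide-type nitrogen. Among the compounds with values here, no pair of measured compounds differs in one place only, so the series offers no direct precedent for this change, and the expectation rests on the spread of three values.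

In this assay the expected step is a 1.3-fold lower number from compound 2 to compound 4 (0.12 log units; within the scatter) as a small estimated fall that stays within the scatter. Within the data shown here, the lean to the lower side rests on compound 3 (0.212 h) as the one value well away from compound 2, which also keeps the range wide. Compound 4 is expected at 0.45 h (estimated range 0.2 h to 0.9 h).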

Compound 4, half-life: 0.365 h
Estimate against measurement, compound 4: 1.2-fold (0.09 log units) above; measured number inside the range.
By their numbers in this assay, from the lowest: compounds 3, 4, 2 and 1 (each within the scatter of the next, the first and the last beyond it).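

In this assay, within the data shown here, thiophen-2-yl in place of 2-fluorophenyl on a saturated chain carbon bound to an amide-type nitrogen gives the first one-place step: a 1.6-fold lower number from compound 2 to compound 4 (0.21 log units; within the scatter). This step stays within the scatter, so a five-membered aromatic ring with 1 hetero atom can stand at this place without a readable shift in half-life from the six-membered carbon-only ring. Nothing measured at hand accounts for the step or shows what the two rings contribute.

This single pair cannot show how far that result extends to other rings at this place. Going by these compounds, the effect on half-life of a pyridine ring, a ring carrying an amine or carboxylic acid, or a longer chain in place of the saturated chain carbon remains open.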